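The source may hold more compounds than are shown below. What is called first, only, known or untested is meant among the compounds shown, and "the series" means these compounds.

Measured so far:
- compound 1, `O=C(N[C@@H]1CCNC1)c1cc(-c2ccc(NS(=O)(=O)c3cccc(Cl)c3Cl)cc2)nc2[nH]ncc12`: < 1 nM
- compound 2, `CNC(=O)c1cc(-c2ccc(NS(=O)(=O)c3cccc(Cl)c3Cl)cc2)nc2[nH]ncc12`: 4 nM
- compound 3, `CCNC(=O)c1cc(-c2ccc(NS(=O)(=O)c3cccc(Cl)c3Cl)cc2)nc2[nH]ncc12`: 6 nM

All three share one core and differ only in the group on the amide nitrogen. In an assay for inhibition of serine/threonine-protein kinase Sgk1 (Homo sapiens), with stated times of 30 min and 60 min, in the presence of a further agent that is not named here (on this read-out higher numbers stand for weaker inhibition and lower numbers for stronger inhibition), compound 1 gives < 1 nM, which is a limit of the assay rather than a number; this is the case described in the limit of < 1 nM in this assay, at which 1 of the 3 values shown sits. In this assay compound 2 gives 4 nM and compound 3 gives 6 nM. The step of a 1.5-fold higher number from compound 2 to compound 3 (0.18 log units; within the scatter) lies within the scatter, so compound 2 and compound 3 cannot be told apart. Against the limit, an at least 4.0-fold higher number from compound 1 to compound 2 (0.60 log units; beyond the scatter) and an at least 6.0-fold higher number from compound 1 to compound 3 (0.77 log units; beyond the scatter) both reach beyond the scatter, so the pyrrolidin-3-yl group goes with a clearly lower number than either small alkyl group.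

Compound 4, `NCCNC(=O)c1cc(-c2ccc(NS(=O)(=O)c3cccc(Cl)c3Cl)cc2)nc2[nH]ncc12`, carries the change (amino in place of hydrogen on a saturated chain carbon, two bonds along the chain from an amide-type nitrogen). Among the compounds with values here, no measured pair shows exactly this change. Compound 1 does show that a nitrogen-containing group on the amide nitrogen gives a lower number than ethyl, so the change is expected to move in the same direction, by a 3.0-fold lower number from compound 3 to compound 4 (0.48 log units; beyond the scatter). Compound 4 is therefore estimated at 2 nM, between 0.6 nM and 7 nM.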

Compound 4, half-maximal inhibitory concentration: < 1 nM
Compound 4: a limit, no number; the forecaster's own chance of this, stated with the estimate: 20%; middle value at least 2.0-fold (0.30 log units) away from the limit.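

In this assay compound 4 gives < 1 nM, which is a limit of the assay and not a number. The amino group on the ethyl chain brings an at least 6.0-fold lower number from compound 3 to compound 4 (0.77 log units; beyond the scatter), and the 2-aminoethyl chain, set against the methyl group, brings an at least 4.0-fold lower number from compound 2 to compound 4 (0.60 log units; beyond the scatter), so the pyrrolidin-3-yl group of compound 1 is not needed for a clearly lower number than the small alkyl groups give. The step between compound 1 and compound 4 cannot be read, since both stand at the same limit: the limit of < 1 nM in this assay, at which 2 of the 4 values shown sit.

From the compounds shown here alone, how far past that limit either compound lies stays open, so the two cannot be placed in order. Going by these compounds, it is also open whether the amine itself matters here, or whether a hydroxyl in its place, a dimethylamino group or a longer chain such as 3-aminopropyl would go with equally low numbers.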